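This account rests on a few compounds, and the source may have more. Where it says the series, first, only, none or still open, it means among the compounds named here.

Values in a functional assay on HeLa cells (Homo sapiens) for inhibition, read by MTT assay, with a stated time of 72 h; a lower number here means a stronger inhibitor, a higher number a weaker inhibitor:
- compound 1 `COc1ccc(C(=O)/C=C/c2cc(OC)c(OC)cc2OC)cc1`: 37600 nM
- compound 2 `COc1cc(OC)c(OC)cc1/C=C/C(=O)c1ccccc1`: > 150000 nM (a limit)
- compound 3 `COc1cc(OC)c(OC)cc1/C=C/C(=O)c1ccc(O)cc1O`: 37600 nM

Compound 3 stands level with compound 1, since no change at the digits printed from compound 1 to compound 3 (within the scatter). Going by the values given here, the only other reading, for compound 2, is a limit and not a number (the limit of > 150000 nM in this assay, at which 1 of the 3 values shown sits).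

The next change leads to compound 4 `COc1cc(OC)c(OC)cc1/C=C/C(=O)c1cc(Cl)ccc1O`, with 5-chloro-2-hydroxyphenyl in place of 2,4-dihydroxyphenyl on a carbonyl carbon.

Among the compounds with values here, two measured steps bear on this group. Going to bare phenyl costs activity, as an at least 3.9-fold higher number from compound 1 to compound 2 (0.60 log units; beyond the scatter), and restoring the 2,4-dihydroxyphenyl group recovers it, as an at least 3.9-fold lower number from compound 2 to compound 3 (0.60 log units; beyond the scatter). Exchanging one substituted group for another left the value unchanged in the step from compound 1 to compound 3. Compound 4 keeps a substituted group, so no step beyond the scatter is expected in this assay. The expected change is a 1.3-fold lower number from compound 3 to compound 4 (0.10 log units; within the scatter). For compound 4 the estimated value is 30000 nM, with an expected range from 10000 nM to 90000 nM.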

Compound 4, half-maximal inhibitory concentration: > 150000 nM
Compound 4 gave a limit, no number (the forecaster's own chance of this, stated with the estimate: 10%); middle value at least 5.0-fold (0.69 log units) away from the limit.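

In this assay, a substituted group on the carbonyl carbon does not by itself preserve activity: an at least 3.9-fold higher number from compound 3 to compound 4 (0.60 log units; beyond the scatter), and an at least 3.9-fold higher number from compound 1 to compound 4 (0.60 log units; beyond the scatter). Among the compounds shown, the 4-methoxyphenyl and 2,4-dihydroxyphenyl groups give the same printed value, whereas compound 4 shows that a substituted group, 5-chloro-2-hydroxyphenyl, can also lose that level. Compound 4 and compound 2 both stand at a limit and not at a number, so the step between them cannot be read: the limit of > 150000 nM in this assay, at which 2 of the 4 values shown sit.

Compound 4 differs from compound 3 by both a chlorine and the loss of a hydroxy group, so the compounds shown do not separate the contribution of each. Also open, on these data alone, is whether 2-hydroxyphenyl without chlorine, or an amine in the chlorine's place, would give a measurable value.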